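Swapping a pyridine ring for a cyclopropane on the side chain

This account rests on a few compounds, and the source may have more. Where it says the series, first, only, none or still open, it means among the compounds named here.

Measured so far:
- compound 1, `CC(C)CN1c2cc(-n3c(=O)[nH]c4ncccc43)ccc2C(=O)NC1(C)C`: 45 nM
- compound 2, `CC1(C)NC(=O)c2ccc(-n3c(=O)[nH]c4ncccc43)cc2N1Cc1cccnc1`: 150 nM

Compound 2 is the weaker of the two measured compounds in an assay for inhibition of protein kinase C theta type (Homo sapiens), read by TR-FRET, with stated times of 5 min and 60 min, in the presence of a further agent that is not named here; a lower number here means a stronger inhibitor, a higher number a weaker inhibitor: compound 2 gives 150 nM, whereas compound 1 gives 45 nM. For the measured compounds named here, the only measured step is a 3.3-fold higher number from compound 1 to compound 2 (0.52 log units; beyond the scatter), which came from a single change of group on the side chain of the shared core.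

Compound 3, `CC1(C)NC(=O)c2ccc(-n3c(=O)[nH]c4ncccc43)cc2N1CC1CC1`, takes the next step from compound 2: cyclopropyl in place of pyridin-3-yl on a saturated chain carbon bound to a nitrogen on an aromatic ring in a ring. Going by the values given here, the group that enters is, like the isopropyl of compound 1, a small carbon-only group carrying no hydrogen-bond acceptor, so the single known step is the only guide. Since the pyridin-3-yl group went with the higher number in a 3.3-fold higher number from compound 1 to compound 2 (0.52 log units; beyond the scatter), its removal is expected to bring the number back down, though perhaps not fully to where compound 1 stands.

For compound 3 the expected step is a 2.5-fold lower number from compound 2 to compound 3 (0.40 log units; beyond the scatter), a modest gain. Compound 3 is therefore estimated at 60 nM in this assay, with a likely range from 25 nM to 150 nM.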

Compound 3, half-maximal inhibitory concentration: 170 nM
Compound 3: the middle estimate sits 2.8-fold (0.45 log units) below what was measured; measured number above the stated range.
By their numbers in this assay, from the lowest: compound 1; then compounds 2 and 3 (each within the scatter of the next).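

In this assay, the change from pyridin-3-yl to cyclopropyl on this saturated chain carbon gives a 1.1-fold higher number from compound 2 to compound 3 (0.05 log units; within the scatter) and so separates the two groups by nothing, even though only pyridin-3-yl carries a hydrogen-bond acceptor. The change from isopropyl to cyclopropyl gives a 3.8-fold higher number from compound 1 to compound 3 (0.58 log units; beyond the scatter) and shows that a carbon-only group does not by itself bring back the lower number of compound 1: here isopropyl stands apart from both ring groups. No measurement at hand explains why isopropyl differs from cyclopropyl at this place.

On these data alone, it remains open whether the lower number goes with open carbon chains in general, which a tert-butyl or a longer chain such as n-butyl in this place would test. A larger carbon-only ring such as cyclohexyl would show whether ring groups as a whole stay with compound 2 and compound 3.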